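The source may report more compounds than this note shows. Statements on the series, on what has been measured and on what is new or still open speak of the compounds shown alone.

Among the compounds with values here, in a physicochemical assay for lipophilicity, at pH 7.4 (on this read-out higher numbers stand for higher lipophilicity and lower numbers for lower lipophilicity), compound 1 (`Cc1cc(C)c(CN2CCc3c(Cl)cc([C@H](CO)[C@H]4CCCO4)c(Cl)c3C2=O)c(=O)[nH]1`) gives 2.1, its only single number, and a further entry for it carries no single number. Compound 2 (`COC(c1cc(Cl)c2c(c1Cl)C(=O)N(Cc1c(C)cc(C)[nH]c1=O)CC2)C1CCS(=O)(=O)CC1`) gives 2.2; 2.2 (2 entries), within the scatter of compound 1. Compound 3 (`Cc1cc(C)c(CN2CCc3c(Cl)cc([C@@H](CO)[C@@H]4CCCO4)c(Cl)c3C2=O)c(=O)[nH]1`) is not yet measured. The change is the two compounds have the same atoms and bonds and differ only in configuration as drawn: 2 of 2 stereo elements differ (all stereocentres are inverted: mirror images); a stereocentre at a saturated chain carbon is drawn R in compound 1 and S in compound 3; a stereocentre at a saturated ring carbon is drawn R in compound 1 and S in compound 3, so the two compounds are mirror images. Within the data shown here, no step between measured compounds is available as a guide. In this assay, no step beyond the scatter and no particular direction are expected, and the estimated step is no change at the digits printed from compound 1 to compound 3 (within the scatter). The expected value for compound 3 is 2.1, with an estimated range from 1.9 to 2.3.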

Compound 3, distribution coefficient: 2.1
Compound 3: the middle estimate sits on the measured number at the digits printed; measured number inside the range.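

In this assay, inverting both stereocentres, the saturated chain carbon and the saturated ring carbon, gives no change at the digits printed from compound 1 to compound 3 (within the scatter). Within the data shown here, this is the first readable step, and the mirror-image pair shows that the read-out does not separate the two fully inverted forms. The comparison isolates a single variable: the fact that compounds 1 and 3 differ only in the configuration as drawn

Still open, on these data alone, is how a compound with only one of the two stereocentres inverted would read in this assay. Also open, as far as these compounds go, is what an amine or a carboxylic acid on the saturated chain carbon would give there.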